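The compounds below may be only part of what the source reports. "The series", "measured", "known", "first", "only" and "open" are said of these compounds alone.

In an assay on microsomes from brain for inhibition of Fatty-acid amide hydrolase 1 (Rattus norvegicus), read by fluorescence and HPLC, with a stated time of 45 min (on this read-out higher numbers stand for weaker inhibition and lower numbers for stronger inhibition), two compounds have been measured. Compound 1 `COC(=O)Nc1ccc2c(cnn2CC(=O)COc2ccc(Oc3ccccc3)cc2)c1` gives 4000 nM, and compound 2 `CCNC(=O)Nc1ccc2c(cnn2CC(=O)COc2ccc(Oc3ccccc3)cc2)c1` gives 1600 nM. Among the compounds with values here, the single step between them, a 2.5-fold lower number from compound 1 to compound 2 (0.40 log units; beyond the scatter), comes from ethylamino in place of methoxy on a carbonyl carbon. Within the data shown here, on these numbers compound 2 stands lowest of the two, with compound 1 as its only neighbour. Compound 3 `CS(=O)(=O)NC(=O)c1ccc2c(cnn2CC(=O)COc2ccc(Oc3ccccc3)cc2)c1` differs from compound 2 by (methylsulfonyl)carbamoyl in place of (ethylcarbamoyl)amino on an aromatic carbon. Among the measured compounds shown here, no measured step tests this particular exchange; the only known step, a 2.5-fold lower number from compound 1 to compound 2 (0.40 log units; beyond the scatter), changed the group hanging from the shared core by a modest amount, so a step of similar or smaller size, or none beyond the scatter, is expected in this assay here. For compound 3 the expected value in this assay is 2000 nM, with a likely range from 600 nM to 7000 nM. That estimate corresponds to the step of a 1.3-fold higher number from compound 2 to compound 3 (0.10 log units; within the scatter).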

Compound 3, half-maximal inhibitory concentration: 770 nM
The estimate for compound 3 lay 2.6-fold (0.41 log units) above the measured number, and the stated range covers the measured number.
By their numbers in this assay, from the lowest: compound 3; then compound 2; then compound 1.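

Within the data shown here, on this aromatic carbon, the earlier compounds varied only the far end of a group attached through nitrogen, whereas (methylsulfonyl)carbamoyl is attached through its carbonyl carbon and brings in a sulfonyl group. This larger change still improves inhibition in this assay, with a 2.1-fold lower number from compound 2 to compound 3 (0.32 log units; beyond the scatter) and a 5.2-fold lower number from compound 1 to compound 3 (0.72 log units; beyond the scatter), so compound 3 has the lowest number of the three and the position tolerates more than a swap at the far end of the group. Nothing available explains why this exchange lowers the number.

The new link and the sulfonyl group arrive together, so their contributions cannot be separated. A carboxylic acid at this carbon, or a longer chain in place of the methyl on the sulfonyl group, could help to tell them apart.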